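Swapping a Benzyl Group for an Amide on the Ring Nitrogen

A few compounds are considered here, and "the series" means these few. Any claim that something is new, unique, unknown or untested is made for them only; others in the source may bear on it.

Of the compounds shown here, two sharing one core have so far been tested in an assay on membranes from Cortex for displacement of a labelled ligand from Sigma non-opioid intracellular receptor 1 (Cavia porcellus), read by scintillation counting, with a stated time of 120 min; a lower number here means a stronger inhibitor, a higher number a weaker inhibitor. Compound 1 `Fc1ccc(C(SCCNC2CCN(Cc3ccc(C(F)(F)F)cc3)CC2)c2ccc(F)cc2)cc1` gives 186 nM, the lower of the two numbers. Compound 2 `CC(C)(C)CN1CCC(NCC[S+]([O-])C(c2ccc(F)cc2)c2ccc(F)cc2)CC1` gives 542 nM, a gap beyond the usual scatter, so compound 1 stands as the stronger inhibitor of this pair. Compound 3 `O=C(c1ccc(F)cc1F)N1CCC(NCCSC(c2ccc(F)cc2)c2ccc(F)cc2)CC1` has not yet been measured. It differs from compound 1 in a single place: (2,4-difluorophenyl)carbonyl in place of 4-(trifluoromethyl)benzyl on an amine nitrogen in a ring. Among the compounds with values here, no measured pair shows what this exchange does, so any expectation rests only on the two values at hand. For compound 3 a weaker inhibition is expected, with a step of an 8.1-fold higher number from compound 1 to compound 3 (0.91 log units; beyond the scatter) that should lie beyond the scatter. Compound 3 is therefore estimated at 1500 nM, with a likely range from 300 nM to 8000 nM, and a measurement will settle this.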

Compound 3, inhibition constant: 20.6 nM
For compound 3 the middle estimate is 73-fold (1.86 log units) above the measured one; measured number below the stated range.
By their numbers in this assay, from the lowest: compound 3; then compound 1; then compound 2.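

In this assay the exchange of 4-(trifluoromethyl)benzyl for (2,4-difluorophenyl)carbonyl on an amine nitrogen in a ring brings a 9.0-fold lower number from compound 1 to compound 3 (0.96 log units; beyond the scatter) and so shifts the number in the stronger direction. Within the data shown here, this position therefore does not need a benzyl group for a low number: a group joined through a carbonyl, with a hydrogen-bond acceptor that the leaving group lacks, gives the lowest number of the series so far. Nothing measured here explains the size of this step.

The exchange alters both the link to the aromatic ring and the fluorine-bearing groups on that ring in one step, so the compounds shown cannot separate the two changes. A 2,4-difluorobenzyl group or a 4-(trifluoromethyl)benzoyl group on this nitrogen would tell them apart.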